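The source may report more compounds than this note shows. Statements on the series, on what has been measured and on what is new or still open speak of the compounds shown alone.

Compound 3 `O=C(C1=C(Nc2cccc(Br)c2)C(=O)N(CCCn2ccnc2)C1c1ccc(Br)cc1)c1ccccc1` holds the lowest of the three numbers measured in a functional assay on NCI-H1299 cells (Homo sapiens) for antiproliferative activity, read by MTT assay, with a stated time of 72 h (on this read-out lower numbers stand for stronger inhibition and higher numbers for weaker inhibition), giving 11500 nM. Its nearest neighbour is compound 2 `CCOc1ccc(NC2=C(C(=O)c3ccccc3)C(c3ccc(Br)cc3)N(CCCn3ccnc3)C2=O)cc1`, which gives 20000 nM in this assay; the gap from compound 2 to compound 3 is a 1.7-fold lower number from compound 2 to compound 3 (0.24 log units; within the scatter). Far behind both stands compound 1 `NC1=C(C(=O)c2ccccc2)C(c2ccc(Br)cc2)N(CCCn2ccnc2)C1=O`, which carries a hydrogen on the amine nitrogen and gives 169000 nM. The steps from compound 1 are the informative ones: an 8.5-fold lower number from compound 1 to compound 2 (0.93 log units; beyond the scatter) and a 15-fold lower number from compound 1 to compound 3 (1.17 log units; beyond the scatter).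

Compound 4 `O=C(C1=C(NCc2ccccc2)C(=O)N(CCCn2ccnc2)C1c1ccc(Br)cc1)c1ccccc1` differs from compound 3 by benzyl in place of 3-bromophenyl on an amine nitrogen. Within the data shown here, no measured step bears directly on swapping one carbon-only aromatic ring for another at this position; the two that exist show only that placing a substituted aryl group on the amine nitrogen, in place of hydrogen, brings a modest to large drop in number, and that exchanging one such aryl group for another stays within the scatter. Benzyl keeps the aromatic ring but is not a measured group here, so compound 4 is expected to remain well away from compound 1, with a possible small rise relative to compound 3 of a 1.7-fold higher number from compound 3 to compound 4 (0.24 log units; within the scatter). Compound 4 is accordingly estimated at 20000 nM, within a range from 7000 nM to 60000 nM.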

Compound 4, half-maximal inhibitory concentration: 25300 nM
Compound 4: the middle estimate sits 1.3-fold (0.10 log units) below what was measured, within the range that was stated.
By their numbers in this assay, from the lowest: compounds 3, 2 and 4 (each within the scatter of the next, the first and the last beyond it); then compound 1.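

With benzyl on the amine nitrogen, compound 4 shows that the drop in number from the hydrogen of compound 1 is not limited to the two substituted phenyl groups, giving a 6.7-fold lower number from compound 1 to compound 4 (0.82 log units; beyond the scatter) in this assay. Among these compounds, the exchange of groups at this nitrogen now matters in one case, as a 2.2-fold higher number from compound 3 to compound 4 (0.34 log units; beyond the scatter) is modest but is the only such exchange among the three ring-bearing groups to pass beyond the scatter, whereas a 1.3-fold higher number from compound 2 to compound 4 (0.10 log units; within the scatter) stays within it, so the position tells 3-bromophenyl from benzyl but not 4-ethoxyphenyl from benzyl. Nothing available accounts for these differences.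

Since 3-bromophenyl and benzyl differ both in the bromine and in the extra carbon, the compounds shown cannot assign the step from compound 3 to compound 4 to either one, and plain phenyl or 3-bromobenzyl on the same nitrogen would separate the two. Also open, on these data alone, is how this nitrogen responds to a group without an aromatic ring, such as a short alkyl chain, or to a longer chain ending in phenyl.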